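The source may hold more compounds than are shown below. What is called first, only, known or untested is meant among the compounds shown, and "the series" means these compounds.

Measured so far in a functional assay on HeLa cells (Homo sapiens) for inhibition, read by sulforhodamine B assay; on this read-out lower numbers stand for stronger inhibition and higher numbers for weaker inhibition:
- compound 1 `CCOc1ccc(NC2=CC(=O)c3c(nc4n3[C@H]3OC[C@@H](O)[C@H]3OC4)C2=O)cc1`: 14400 nM
- compound 2 `Cc1ccc(NC2=CC(=O)c3c(nc4n3[C@H]3OC[C@@H](O)[C@H]3OC4)C2=O)cc1`: 6590 nM
- compound 3 `O=C1C(N2CCCC2)=CC(=O)c2c1nc1n2[C@H]2OC[C@@H](O)[C@H]2OC1`: > 16000 nM

Compound 3 stands only at a limit of this assay, > 16000 nM, which is the limit of > 16000 nM in this assay, at which 1 of the 3 values shown sits; no number is known for it. Among the numbers in hand, compound 2 gives 6590 nM and compound 1 gives 14400 nM. The measured steps are a 2.2-fold lower number from compound 1 to compound 2 (0.34 log units; beyond the scatter) and an at least 2.4-fold higher number from compound 2 to compound 3 (0.38 log units; beyond the scatter).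

Compound 4 `CCc1ccc(NC2=CC(=O)c3c(nc4n3[C@H]3OC[C@@H](O)[C@H]3OC4)C2=O)cc1` is not yet measured in this assay. It differs from compound 3 by (4-ethylphenyl)amino in place of pyrrolidin-1-yl on a double-bonded ring carbon. The step that bears on this most directly is an at least 2.4-fold higher number from compound 2 to compound 3 (0.38 log units; beyond the scatter), which runs the same exchange of ring amine for arylamine in the opposite direction; reversed, it points to a lower number for compound 4 of at least that size. The step of a 2.2-fold lower number from compound 1 to compound 2 (0.34 log units; beyond the scatter) concerns only the group on the aromatic carbon, and ethyl is closer to methyl than to ethoxy in that comparison, so compound 4 is expected to land near compound 2. Compound 4 is therefore expected at 7000 nM, in the range 3000 nM to 16000 nM, a step estimated as an at least 2.2-fold lower number from compound 3 to compound 4 (0.35 log units; beyond the scatter).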

Compound 4, half-maximal inhibitory concentration: 6510 nM
Estimate against measurement, compound 4: 1.1-fold (0.03 log units) above; measured number inside the range.
By their numbers in this assay, from the lowest: compounds 4 and 2 (each within the scatter of the next); then compound 1. At a limit, above all of these: compound 3.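

In this assay, (4-ethylphenyl)amino in place of pyrrolidin-1-yl on the double-bonded ring carbon gives an at least 2.4-fold lower number from compound 3 to compound 4 (0.39 log units; beyond the scatter), so a second arylamine now reads apart from the ring amine and the earlier comparison no longer rests on compound 2 alone. The size of that step is only a bound, as compound 3 stands at a limit and has no number: the limit of > 16000 nM in this assay, at which 1 of the 4 values shown sits. On the aromatic carbon, ethyl and methyl cannot be told apart, with a 1.0-fold lower number from compound 2 to compound 4 (0.01 log units; within the scatter), whereas ethyl in place of ethoxy gives a 2.2-fold lower number from compound 1 to compound 4 (0.34 log units; beyond the scatter), which places compounds 2 and 4 together and compound 1 apart.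

From the compounds shown here alone, whether the difference at the double-bonded ring carbon follows the aromatic ring or the amine hydrogen remains open, and an open-chain amine such as diethylamino or a benzylamino group would bear on this. Going by these compounds, how chlorine or a carboxylic acid on the aromatic carbon would read also remains open.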